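Swapping an alkyl chain for a fluorinated aromatic ring

The source may hold more compounds than are shown below. What is called first, only, known or untested is meant among the compounds shown, and "the series" means these compounds.

In a functional assay on Huh-7 cells (Homo sapiens) for inhibition, read by sulforhodamine B assay (on this read-out higher numbers stand for weaker inhibition and lower numbers for stronger inhibition), the three measured compounds give the following numbers:
compound 1 `C#CC(=O)N1C(c2ccc(C#N)cc2)SC[C@@H]1C(=O)OCC` gives 2600 nM
compound 2 `C#CC(=O)N1C(C(CC)CCCC)SC[C@@H]1C(=O)OCC` gives 1700 nM
compound 3 `C#CC(=O)N1C(c2ccccc2F)SC[C@@H]1C(=O)OCC` gives 1700 nM

Compound 2 and compound 3 share the same number, and the gap between compound 2 and compound 1 is within the scatter, so the three compounds cannot be told apart on these numbers.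

Compound 4 `C#CC(=O)N1C(c2ccc(F)cc2)SC[C@@H]1C(=O)OCC` has not yet been measured. It differs from compound 2 by 4-fluorophenyl in place of 1-ethylpentyl on a saturated ring carbon. Going by the values given here, the one measured step that bears on this is no change at the digits printed from compound 2 to compound 3 (within the scatter), where an aromatic ring with fluorine also took the place of the same alkyl chain on that same ring carbon and the number did not move. Compound 1 with its nitrile-bearing ring likewise sits close to compound 2. The expected step of a 1.1-fold higher number from compound 2 to compound 4 (0.02 log units; within the scatter) is therefore no change beyond the scatter. Compound 4 is expected to give about 1800 nM, with a likely range from 900 nM to 3600 nM.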

Compound 4, half-maximal inhibitory concentration: 700 nM
Compound 4: the middle estimate sits 2.6-fold (0.41 log units) above what was measured; the measured number lies below the stated range.
By their numbers in this assay, from the lowest: compound 4; then compounds 2, 3 and 1 (each within the scatter of the next).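

On this assay, the group on this saturated ring carbon does affect the number: 4-fluorophenyl in place of 1-ethylpentyl gives a 2.4-fold lower number from compound 2 to compound 4 (0.39 log units; beyond the scatter). An aromatic ring with fluorine is not enough on its own, as the 2-fluorophenyl group gave no change at the digits printed from compound 2 to compound 3 (within the scatter), while 4-fluorophenyl in place of 2-fluorophenyl gives a 2.4-fold lower number from compound 3 to compound 4 (0.39 log units; beyond the scatter). The group on the aromatic ring counts as well: fluoro in place of cyano gives a 3.7-fold lower number from compound 1 to compound 4 (0.57 log units; beyond the scatter). Nothing available explains why these changes move the number.

As far as these compounds go, whether an unsubstituted phenyl, a 3-fluorophenyl or a 4-chlorophenyl group would give a number as low as compound 4 remains open. Also open, from the compounds shown here alone, is whether this order of compounds carries over to any other cell type.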